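N-methylation of the ring amide in a dihydropyrimidinone ester series

A few compounds are considered here, and "the series" means these few. Any claim that something is new, unique, unknown or untested is made for them only; others in the source may bear on it.

Measured compounds:
compound 1 `CCCOC(=O)C1=C(C)NC(=O)NC1c1ccoc1` — 50%
compound 2 `CC1=C(C(=O)OC(C)(C)C)C(c2ccoc2)NC(=O)N1` — 11%

In an assay on membranes from CHO cells for displacement of a labelled ligand from adenosine receptor A1 (Homo sapiens), read by scintillation counting, with a stated time of 60 min, tested at 1 uM (on this read-out lower numbers stand for less inhibition and higher numbers for more inhibition at the one concentration tested (going by the name of the read-out)), compound 1 gives 50%, the higher of the two numbers; compound 2 gives 11%. Among the compounds with values here, the one measured step, a number 39 percentage points lower from compound 1 to compound 2 (beyond the scatter), concerns the ester only. Compound 3 `CCCOC(=O)C1=C(C)N(C)C(=O)NC1c1ccoc1` differs from compound 1 by methyl in place of hydrogen on an amide-type nitrogen in a ring. Within the data shown here, no measured step touches this ring nitrogen, so the ester step is not a direct guide; the expectation rests on compound 1 alone with wide uncertainty. A moderate drop is expected, a number 15 percentage points lower from compound 1 to compound 3 (beyond the scatter), giving an estimate for compound 3 of 35%, within 10% to 60%.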

Compound 3, a percentage reported as inhibition, at one concentration (the size of the read-out at that concentration, not a potency): 1%
Beside the measured number, compound 3's estimate is 34 percentage points above it; measured number outside the range, below it.
By their numbers in this assay, from the lowest: compounds 3 and 2 (each within the scatter of the next); then compound 1.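

In this assay methyl in place of hydrogen on the amide-type nitrogen in the ring gives a number 49 percentage points lower from compound 1 to compound 3 (beyond the scatter) with the propoxycarbonyl and furan-3-yl groups unchanged. This shows that the read-out is sensitive to a change away from the ester, as a single added carbon on this nitrogen brings compound 3 within the scatter of compound 2. Nothing available explains this loss.

As far as these compounds go, whether an ethyl or an acetyl group on this nitrogen would give a similar read-out stays open. Also open, from the compounds shown here alone, is how this methyl would behave alongside the tert-butyl ester of compound 2.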